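The source may report more compounds than this note shows. Statements on the series, on what has been measured and on what is new or still open speak of the compounds shown alone.

Working notes on the series

Of the compounds shown here, three carry numbers so far. Compound 1 `Nc1nc(N)c2cc(NCc3ccc(C(=O)N[C@@H](CCC(=O)O)C(=O)O)cc3)ccc2n1` is the glutamate-bearing member; in an assay for inhibition of Dihydrofolate reductase (Homo sapiens) (a higher number here means a more potent compound, by a factor of ten per unit of this negative logarithm, a lower number a less potent compound), compound 1 gives 7.59. Compound 2 `Nc1nc(N)c2c(Cl)c(NC(=O)CCc3ccc(Cl)cc3)ccc2n1` carries a chloro on the fused carbocycle of the shared core and a propanamide chain to a chlorophenyl; in this assay compound 2 gives 7.44. Compound 3 `CC(=O)Nc1nc(O)c2cc(S(=O)(=O)c3ccc4ccccc4c3)ccc2n1` differs from both at the core and in the sulfonyl linker; in this assay compound 3 gives 6.11.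

Compound 2 and compound 1 sit within the usual scatter of each other, so no order between them can be read. Compound 3 lies well below both, beyond the scatter, and is the weakest of the three.

Compound 4 `Nc1nc(N)c2cc(NC(=O)CCc3ccc(Cl)cc3)ccc2n1` is the next member to be measured, and it differs from compound 2 in one place: hydrogen in place of chloro on an aromatic carbon. For the measured compounds named here, no measured pair in the set shows this change on its own, so there is no internal step to lean on; the expectation rests on compound 2 alone.

The step from compound 2 to compound 4 is expected to be modest, most likely a small loss in this assay, and may not exceed the scatter: a number 0.44 log units lower from compound 2 to compound 4 (beyond the scatter). Compound 4 is accordingly estimated at 7 in this assay, within a range of 6.4 to 7.6.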

Compound 4, logarithm of the reciprocal of the active concentration, log(1/C): 7.33
Beside the measured number, compound 4's estimate is 0.33 log units below it; the measured number falls inside the stated range.
By their numbers in this assay, from the lowest: compound 3; then compounds 4, 2 and 1 (each within the scatter of the next).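

In this assay, for the compounds shown here, hydrogen in place of chloro on an aromatic carbon gives a number 0.11 log units lower from compound 2 to compound 4 (within the scatter), the first reading of this change on its own. At this place, ortho to a fused ring and ortho to a large group, the chloro is therefore not needed for a number in this range, since compound 4 stands within the scatter of compound 2 without it; this single pair cannot tell a small contribution from the chloro apart from none at all. Nothing available bears on the reason for this result.

The compounds shown hold only chloro and hydrogen at this place, so what a methyl, a methoxy, an amine or a carboxylic acid would do there remains open. Also open, on these data alone, is whether the same exchange would read the same on compounds with a different side chain, such as a longer chain in place of the propanamide or the glutamate-bearing chain of compound 1.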